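The compounds below may be only part of what the source reports. "The series", "measured", "known", "first", "only" and "open" are said of these compounds alone.

Measured in a functional assay on HeLa cells (Homo sapiens) for cytotoxicity, in the presence of a further agent that is not named here; on this read-out higher numbers stand for weaker inhibition and lower numbers for stronger inhibition:
- compound 1 `Clc1ccc(-c2cc(-c3ccsc3)nc(-c3ccccc3Cl)c2)o1`: 8070 nM
- compound 2 `Clc1ccc(-c2cc(-c3cccs3)nc(-c3ccccc3Cl)c2)o1`: 18500 nM
- compound 3 `Clc1ccc(-c2cc(-c3ccco3)cc(-c3cccs3)n2)cc1`: 32700 nM

Compound 1 has the lowest of these three numbers in this assay. Compound 4 `Cc1ccc(-c2cc(-c3ccc(Cl)o3)cc(-c3ccsc3)n2)cc1` keeps the core of compound 1 but carries 4-methylphenyl in place of 2-chlorophenyl on an aromatic carbon, next to the ring nitrogen: 4-methylphenyl in place of 2-chlorophenyl on an aromatic carbon. Among the measured compounds shown here, no measured step covers this change. The only one, a 2.3-fold higher number from compound 1 to compound 2 (0.36 log units; beyond the scatter), is modest and concerns the thiophene group instead. Compound 3 differs from compound 1 in more than one place, so it isolates no single change. With so little evidence, only a small step toward a higher number is expected, no larger than that thiophene step. The expected step is a 1.9-fold higher number from compound 1 to compound 4 (0.27 log units; within the scatter). For compound 4 the estimate is 15000 nM, with an expected range from 5000 nM to 40000 nM.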

Compound 4, half-maximal inhibitory concentration: 16200 nM
Estimate against measurement, compound 4: 1.1-fold (0.03 log units) below; measured number inside the range.
By their numbers in this assay, from the lowest: compounds 1, 4, 2 and 3 (each within the scatter of the next, the first and the last beyond it).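

In this assay, among the compounds shown here, the first reading at this position, on an aromatic carbon next to the ring nitrogen, shows a 2.0-fold higher number from compound 1 to compound 4 (0.30 log units; within the scatter) for 4-methylphenyl in place of 2-chlorophenyl. This exchange of one aryl group for another therefore leaves the number within the scatter. The step alters the ring substituent and its place together, so it cannot separate the two, and nothing available accounts for the result.

As far as these compounds go, whether an amine or a carboxylic acid on this phenyl ring would move the number beyond the scatter remains open. So does whether 4-methylphenyl gives a similar step alongside thiophen-2-yl.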